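The source may report more compounds than this note shows. Statements on the series, on what has been measured and on what is new or still open speak of the compounds shown alone.

The compounds share one core, differing only in the groups attached to it. Compound 1 `COc1ccccc1Oc1c(N)nc(-c2cccc(C)c2)nc1Cl` gives 13100 nM in a functional assay on B16 cells (Mus musculus) for cytotoxicity, read by CCK-8 assay, with a stated time of 24 h; on this read-out higher numbers stand for weaker inhibition and lower numbers for stronger inhibition. Compound 2 `COc1ccccc1Oc1c(N)nc(-c2cccc(I)c2)nc1Cl` gives 27600 nM in the same assay, and compound 3 `COc1ccccc1Oc1c(N)nc(-c2cccc(C)c2)nc1OCCO` gives 70900 nM, the highest of the three numbers, which on this read-out means the weakest inhibition of the three.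

Two single changes have been measured. The step of a 5.4-fold higher number from compound 1 to compound 3 (0.73 log units; beyond the scatter) is the larger one. The step of a 2.1-fold higher number from compound 1 to compound 2 (0.32 log units; beyond the scatter) is smaller, and it is the one that bears on the next compound, since it too swaps a halogen for a methyl on the phenyl ring attached to the core.

Compound 4 `COc1ccccc1Oc1c(N)nc(-c2ccc(Br)cc2)nc1OCCO` differs from compound 3 by 4-bromophenyl in place of 3-methylphenyl on an aromatic carbon. Within the data shown here, no measured pair swaps a 3-methylphenyl for a 4-bromophenyl, so the expectation rests on the halogen-for-methyl step seen with compound 2. By analogy, a modest step toward a higher number is expected, a 1.8-fold higher number from compound 3 to compound 4 (0.26 log units; within the scatter). Compound 4 is therefore estimated at 130000 nM, within a range from 50000 nM to 300000 nM.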

Compound 4, half-maximal inhibitory concentration: 11800 nM
Compound 4: the middle estimate sits 11-fold (1.04 log units) above what was measured, outside the stated range (below it).
By their numbers in this assay, from the lowest: compounds 4 and 1 (each within the scatter of the next); then compound 2; then compound 3.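

In this assay, swapping 3-methylphenyl for 4-bromophenyl on the carbon between two ring nitrogen atoms gives a 6.0-fold lower number from compound 3 to compound 4 (0.78 log units; beyond the scatter), so a halogen on this phenyl ring can go with a lower number as well as a higher one. The earlier change of iodo in place of methyl went the other way, with a 2.1-fold higher number from compound 1 to compound 2 (0.32 log units; beyond the scatter), but it kept the group's place on the phenyl ring and had chloro on the core where compound 4 has 2-hydroxyethoxy. No measurement shown here accounts for this difference in direction.

Compound 4 changes both the halogen and its place on the phenyl ring, so the compounds shown leave open which of the two matters. A 3-bromophenyl or a 4-methylphenyl group on the 2-hydroxyethoxy core would separate them.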